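Nitro to amino on a styryl-type core and an amide core

A few compounds are considered here, and "the series" means these few. Any claim that something is new, unique, unknown or untested is made for them only; others in the source may bear on it.

Compound 1 `COc1ccc(CS(=O)(=O)/C=C/c2c(OC)cccc2OC)cc1[N+](=O)[O-]` in a functional assay on MDA-MB-468 cells (Homo sapiens) for cytotoxicity, read by MTT assay, with a stated time of 72 h (on this read-out higher numbers stand for weaker inhibition of growth and lower numbers for stronger inhibition of growth), gives 5460 nM. Compound 2 `COc1ccc(CS(=O)(=O)CC(=O)Nc2c(C)cc(C)cc2C)cc1[N+](=O)[O-]` has a different core; the difference between the two cores is not broken down here. In this assay compound 2 reaches only the limit > 30000 nM. Compound 3 `COc1ccc(CS(=O)(=O)CC(=O)Nc2c(C)cc(C)cc2C)cc1N` differs from compound 2 by amino in place of nitro on an aromatic carbon. Compound 3 also gives only the limit > 30000 nM. The step that the two limits leave unreadable from compound 2 to compound 3 therefore cannot be read, because both values sit at the limit of > 30000 nM in this assay, at which 2 of the 3 values shown sit. Compound 4 `COc1ccc(CS(=O)(=O)/C=C/c2c(OC)cccc2OC)cc1N` differs from compound 1 by amino in place of nitro on an aromatic carbon, the same change. With the measured step unreadable, the expected step of a 1.4-fold lower number from compound 1 to compound 4 (0.14 log units; within the scatter) rests only on compound 1 at 5460 nM and carries wide uncertainty. Compound 4 is estimated at 4000 nM, between 700 nM and 22000 nM.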

Compound 4, concentration for 50% growth inhibition: 60 nM
Estimate against measurement, compound 4: 67-fold (1.82 log units) above; the measured number lies below the stated range.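

In this assay, amino in place of nitro on an aromatic carbon gives a 91-fold lower number from compound 1 to compound 4 (1.96 log units; beyond the scatter) and so matters greatly on the core of compound 1. On the amide core of compound 2 and compound 3 the same change cannot be read, because both compounds give only a limit of the assay and not a number: the limit of > 30000 nM in this assay, at which 2 of the 4 values shown sit. The large step is therefore known on one core only, and the series shows neither that the change carries over to the other core nor that it fails to.

The compounds shown leave open how a hydroxyl or a dimethylamino group in the same place would compare with the amino group of compound 4. They also leave open whether the step would recur on a third core.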